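Methyl added to the ring of compound 1

This account rests on a few compounds, and the source may have more. Where it says the series, first, only, none or still open, it means among the compounds named here.

Compound 1 `Cc1c2c(n3c1CCCNC[C@H](C)Nc1cc-3ccc1C(N)=O)CC(C)(C)CC2=O` gives 93 nM in a functional assay on HCT-116 cells (Homo sapiens) for antiproliferative activity; on this read-out lower numbers stand for stronger inhibition and higher numbers for weaker inhibition. Among the compounds with values here, this is the lower of the two numbers measured so far, and the gap to compound 2 `Cc1c2c(n3c1CCN(C(=O)[C@H](C)N)CC[C@H](C)Nc1cc-3ccc1C(N)=O)CC(C)(C)CC2=O` at 314 nM lies beyond the scatter. Compound 3 `Cc1c2c(n3c1CCCN[C@@H](C)[C@H](C)Nc1cc-3ccc1C(N)=O)CC(C)(C)CC2=O` has not yet been measured. Its structure departs from compound 1 by a single change: methyl in place of hydrogen on a saturated ring carbon. Within the data shown here, no measured pair isolates this change, so the expectation rests on compound 1 at 93 nM as the only close anchor, and it stays loose. In this assay, no step beyond the scatter is expected, and the estimated change is a 1.4-fold higher number from compound 1 to compound 3 (0.15 log units; within the scatter). For compound 3 the expected value is 130 nM, with an estimated range of 40 nM to 450 nM.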

Compound 3, half-maximal inhibitory concentration: 29 nM
Compound 3: the middle estimate sits 4.5-fold (0.65 log units) above what was measured; the whole stated range lies above it.
By their numbers in this assay, from the lowest: compound 3; then compound 1; then compound 2.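

Methyl in place of hydrogen on this saturated ring carbon gives a 3.2-fold lower number from compound 1 to compound 3 (0.51 log units; beyond the scatter) in this assay and so shows that this position, next to the ring nitrogen and next to the ring atom that bears a methyl group, tolerates an added carbon without loss of antiproliferative activity. Within the data shown here, it is also the first measured step that isolates a single change on this ring, and it runs towards a lower number. No measurement at hand speaks to the origin of this step.

On these data alone, only one configuration of the new methyl group appears here, so the outcome with the opposite configuration at this carbon remains open. Whether a larger or functionalised group, such as ethyl or hydroxymethyl, would preserve the step is also unresolved.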